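This account rests on a few compounds, and the source may have more. Where it says the series, first, only, none or still open, it means among the compounds named here.

Among the compounds with values here, compound 1 `Cc1ccnc(NC(=O)c2ccccc2C)c1` is one of two compounds measured in a physicochemical assay for lipophilicity, read by HPLC, at pH 7.4; a lower number here means a more polar compound, a higher number a more lipophilic compound. In this assay compound 1 gives 2.8, the lower of the two numbers. Its nearest neighbour is compound 2 `Cc1cc(Br)ccc1C(=O)Nc1ccccn1`, and in this assay compound 2 gives 3.2, a number higher than that of compound 1 by more than the usual scatter; the two structures differ in more than one place, so this pair shows nothing beyond the two values themselves.

Compound 3 `Cc1ccccc1C(=O)Nc1cc(C#N)ccn1` has not yet been measured. It differs from compound 1 in one place: cyano in place of methyl on an aromatic carbon. Within the data shown here, no measured pair shows this change, so the size of its step rests on expectation alone. The step is expected to run downward and to reach beyond the scatter, estimated as a number 0.90 log units lower from compound 1 to compound 3 (beyond the scatter). Compound 3 is therefore expected to give about 1.9 in this assay, within a range from 1.4 to 2.4.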

Compound 3, distribution coefficient: 2.8
The estimate for compound 3 lay 0.90 log units below the measured number; measured number outside the range, above it.
By their numbers in this assay, from the lowest: compounds 1 and 3 (each within the scatter of the next); then compound 2.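

Within the data shown here, compound 1 and compound 2 differ in more than one place, so the pair of compound 1 and compound 3 gives the first comparison that isolates a single change. On the aromatic carbon opposite the ring nitrogen, cyano in place of methyl gives no change at the digits printed from compound 1 to compound 3 (within the scatter) in this assay, so here a group with one hydrogen-bond acceptor stands where a group with none stood, and the two compounds cannot be told apart by their numbers. Nothing at hand bears on the reason for this result.

On these data alone, this single pair speaks for one position on one core, and whether the same holds elsewhere on the core remains open. Also open, as far as these compounds go, is where an amine, a carboxylic acid or a longer alkyl chain at this same position would fall in this assay.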